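Trifluoromethyl Added to the Anilide Ring of a Urea

A few compounds are considered here, and "the series" means these few. Any claim that something is new, unique, unknown or untested is made for them only; others in the source may bear on it.

Compound 1 (`CC(C)(C)[C@H]1CC[C@H](N(Cc2ccc(C(=O)NCCC(=O)O)cc2)C(=O)Nc2ccc(C#N)cc2)CC1`): 1050 nM
Compound 2 (`CC(C)(C)[C@H]1CC[C@H](N(Cc2ccc(C(=O)NCCC(=O)O)cc2)C(=O)Nc2ccc(OCC3CC3)cc2)CC1`): 140 nM

Both compounds were tested in an in vitro assay on BHK cells for inhibition of Glucagon receptor (Homo sapiens); a lower number here means a stronger inhibitor, a higher number a weaker inhibitor. They differ in a single place, and that step is a 7.5-fold lower number from compound 1 to compound 2 (0.88 log units; beyond the scatter). Compound 2 therefore stands with the lowest of the two numbers, its nearest neighbour being compound 1 at a clearly higher value.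

Compound 3 (`CC(C)(C)[C@H]1CC[C@H](N(Cc2ccc(C(=O)NCCC(=O)O)cc2)C(=O)Nc2ccc(OCC3CC3)cc2C(F)(F)F)CC1`) departs from compound 2 in one place: trifluoromethyl in place of hydrogen on an aromatic carbon. Among the compounds with values here, no measured step bears on this particular change; the single step on record concerns a different group at a different aromatic carbon and offers no direct guide. With nothing to anchor a direction, the expectation is a step of a 1.3-fold lower number from compound 2 to compound 3 (0.10 log units; within the scatter) in this assay, lying within the scatter. Compound 3 is accordingly estimated at 110 nM, with a plausible range from 35 nM to 350 nM.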

Compound 3, half-maximal inhibitory concentration: 182 nM
Beside the measured number, compound 3's estimate is 1.7-fold (0.22 log units) below it; measured number inside the range.
By their numbers in this assay, from the lowest: compounds 2 and 3 (each within the scatter of the next); then compound 1.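

Placing trifluoromethyl on this aromatic carbon, ortho to a large group and meta to a cyclopropylmethoxy group, gives a 1.3-fold higher number from compound 2 to compound 3 (0.11 log units; within the scatter) in this assay, so compound 2 and compound 3 cannot be told apart in this read-out. This position therefore takes a group of 4 heavy atoms in place of a lone hydrogen, at least with the cyclopropylmethoxy group present, and the number stays within the scatter. Nothing measured here offers an explanation for this result.

Open, on these data alone, is how other groups on this same aromatic carbon would read, such as a chlorine atom, a methoxy group or an amine. Also open, as far as these compounds go, is whether trifluoromethyl here would give a similar result with the nitrile of compound 1 in place of the cyclopropylmethoxy group.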